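The compounds below may be only part of what the source reports. "The series", "measured", "known", "first", "only" and "open" are said of these compounds alone.

In a physicochemical assay for solubility, with a stated time of 4 h, at pH 2.0 (a higher number here means a more soluble compound, a lower number a less soluble compound), compound 1 `Cc1cc(CCC#N)cc(C)c1Oc1cc(Nc2ccc(C#N)cc2)c(N)cc1C(N)=O` gives 9.11 ug/mL. Compound 2 `Cc1cc(/C=C/C#N)cc(C)c1Oc1cc(Nc2ccc(C#N)cc2)c(N)cc1CO` gives 20.9 ug/mL. Compound 3 `Cc1cc(/C=C/C#N)cc(C)c1Oc1cc(Nc2ccc(C#N)cc2)c(N)cc1[N+](=O)[O-]` gives 0.29 ug/mL.

Compound 3 therefore stands lowest of the three numbers, with compound 1 nearest and compound 2 furthest, both gaps lying beyond the scatter. The step to compound 4 `Cc1cc(/C=C/C#N)cc(C)c1Oc1cc(Nc2ccc(C#N)cc2)c(N)cc1C(N)=O` is carbamoyl in place of nitro on an aromatic carbon. Among the measured compounds shown here, one measured step bears on it: a 72-fold lower number from compound 2 to compound 3 (1.86 log units; beyond the scatter), where the nitro entered. Taking the nitro out again is expected to recover much of that loss, and compound 1, which already carries the carbamoyl, shows a number well above compound 3. Compound 4 is thus expected to rise by a 31-fold higher number from compound 3 to compound 4 (1.49 log units; beyond the scatter), to an estimated 9 ug/mL with a range of 3 ug/mL to 25 ug/mL.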

Compound 4, solubility: 2.09 ug/mL
The estimate for compound 4 lay 4.3-fold (0.63 log units) above the measured number; measured number below the stated range.
By their numbers in this assay, from the lowest: compound 3; then compound 4; then compound 1; then compound 2.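

At this aromatic carbon in this assay, carbamoyl in place of nitro gives a 7.2-fold higher number from compound 3 to compound 4 (0.86 log units; beyond the scatter) and so recovers only part of the gap to hydroxymethyl. Carbamoyl in place of hydroxymethyl gives a 10-fold lower number from compound 2 to compound 4 (1.00 log units; beyond the scatter) at the same carbon, which places the three groups in the order nitro, carbamoyl, hydroxymethyl on this core. With carbamoyl held constant, 2-cyanoethenyl in place of 2-cyanoethyl gives a 4.4-fold lower number from compound 1 to compound 4 (0.64 log units; beyond the scatter) and shows that the number also moves with that chain. Where an aminomethyl group or a carboxylic acid at this aromatic carbon would fall in that order remains open. Nothing shown accounts for these differences.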